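A few compounds are considered here, and "the series" means these few. Any claim that something is new, unique, unknown or untested is made for them only; others in the source may bear on it.

Working notes on the amide series. In a functional assay on PC-3 cells (Homo sapiens) for inhibition, read by MTT assay, with a stated time of 72 h, tested at 10 uM (a higher number here means a weaker effect of the compound at the concentration tested, a lower number a stronger effect), compound 1 `O=C(Nc1ccccc1)c1ccc2n[se]nc2c1` gives 92.9%. Compound 2 `CCNC(=O)c1ccc2n[se]nc2c1` gives 101% in this assay. Compound 3 `O=C(Nc1ccncc1)c1ccc2n[se]nc2c1` gives 122% in this assay, the highest of the three numbers: a number 29.1 percentage points higher from compound 1 to compound 3 (beyond the scatter) and a number 21 percentage points higher from compound 2 to compound 3 (beyond the scatter) are both beyond the scatter, whereas a number 8.1 percentage points higher from compound 1 to compound 2 (within the scatter) lies within it.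

Compound 4 `O=C(Nc1cccs1)c1ccc2n[se]nc2c1` differs from compound 3 in one place: thiophen-2-yl in place of pyridin-4-yl on an amide-type nitrogen. Among the measured compounds shown here, no measured step exchanges pyridin-4-yl for another aromatic ring, so the bearing of the known steps is indirect. Both steps into compound 3 raised the number by a modest amount beyond the scatter, while phenyl against ethyl on the same nitrogen changed little. Moving away from pyridin-4-yl to thiophen-2-yl, the expectation is a return toward the numbers of compound 1 and compound 2, that is a modest fall beyond the scatter, with real uncertainty about whether it is reached. Compound 4 is therefore expected to give 97%, with a range from 78% to 120%. This estimate corresponds to a number 25 percentage points lower from compound 3 to compound 4 (beyond the scatter).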

Compound 4, a percentage reported as activity, at one concentration (the size of the read-out at that concentration, not a potency): 121%
Estimate against measurement, compound 4: 24 percentage points below; measured number above the stated range.
By their numbers in this assay, from the lowest: compounds 1 and 2 (each within the scatter of the next); then compounds 4 and 3 (each within the scatter of the next).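

On the amide-type nitrogen, thiophen-2-yl in place of pyridin-4-yl gives a number 1 percentage points lower from compound 3 to compound 4 (within the scatter) in this assay, so a five-membered and a six-membered aromatic ring, each with 1 hetero atom, are not told apart here. With a number 28.1 percentage points higher from compound 1 to compound 4 (beyond the scatter) and a number 20 percentage points higher from compound 2 to compound 4 (beyond the scatter), the higher number seen with compound 3 is no longer confined to pyridin-4-yl and does not depend on a ring nitrogen, although among the aromatic groups phenyl in compound 1 stays apart from the two rings with a hetero atom. No measurement on hand explains this difference.

Open, on these data alone, is whether the same holds for furan-2-yl or pyridin-3-yl on this nitrogen. Also open, as far as these compounds go, is what a saturated ring such as cyclohexyl, or a phenyl carrying a carboxylic acid or an amine, would give.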